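Working notes: the step from compound 2 to compound 3

The compounds below may be only part of what the source reports. "The series", "measured", "known", "first", "only" and "open" are said of these compounds alone.

Compound 1 `CC(=O)N1CCC(n2cc(-c3cnc(N)c4oc(-c5cnc6cnccn56)cc34)cn2)CC1` and compound 2 `CC(=O)N1CCC(n2cc(-c3cnc(N)c4oc(-c5cccc6ccccc56)cc34)cn2)CC1` share one core and differ only in the group on the five-membered aromatic ring of that core. In an ADME assay on microsomes from liver (Homo sapiens) for metabolic stability (a lower number here means that the liver removes a smaller share, a higher number that the liver removes a larger share of the compound in one pass), compound 1 gives 0, and compound 2 gives 0.66. Among the measured compounds shown here, compound 2 therefore stands highest of the two numbers measured so far, separated from compound 1 by a step beyond the scatter. Compound 3 `CC(=O)N1CCC(n2cc(-c3cnc(N)c4oc(-c5cccc6nnsc56)cc34)cn2)CC1` has not yet been measured. Relative to compound 2 the change is a group of 9 heavy atoms (6 carbon, 2 nitrogen, 1 sulfur; one five-membered aromatic ring with 3 hetero atoms, one six-membered aromatic ring of carbon only) in place of a group of 10 heavy atoms (10 carbon; 2 six-membered aromatic rings of carbon only), on an aromatic carbon. For the measured compounds named here, the one measured step that bears on this is a number 0.66 higher from compound 1 to compound 2 (beyond the scatter), in which a group of 9 heavy atoms with two rings carrying hetero atoms gave way to the naphthalen-1-yl group and the number rose by a large amount. The change to compound 3 runs partway back: the naphthalen-1-yl group leaves and a group of 9 heavy atoms with one five-membered aromatic ring with 3 hetero atoms enters. A drop in this assay beyond the scatter is therefore expected, though not a full return to compound 1. Compound 3 is expected to give 0.35, in the range 0.1 to 0.6. The expected step is a number 0.31 lower from compound 2 to compound 3 (beyond the scatter).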

Compound 3, hepatic extraction ratio: 0.68
Compound 3: the middle estimate sits 0.33 below what was measured; measured number above the stated range.
By their numbers in this assay, from the lowest: compound 1; then compounds 2 and 3 (each within the scatter of the next).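

In this assay, the step on exchanging naphthalen-1-yl for the entering group, on an aromatic carbon next to the ring oxygen, is a number 0.020 higher from compound 2 to compound 3 (within the scatter), so these two groups cannot be told apart at this position. Hetero atoms in the group are therefore not enough in themselves to separate a compound from compound 2: the entering group has a five-membered aromatic ring with 3 hetero atoms and 3 hydrogen-bond acceptors, yet the step from the group of compound 1 is a number 0.68 higher from compound 1 to compound 3 (beyond the scatter), and only compound 1 stands apart among the three. Nothing available explains why the group of compound 1 differs from the other two in this assay.

The group of compound 1 has hetero atoms in both of its rings, so these compounds do not show whether its five-membered ring, its six-membered ring or the two together go with the low number. As far as these compounds go, it also remains open where a bicyclic group with nitrogen only in the six-membered ring, such as quinolinyl, or a single ring such as pyridinyl or phenyl, would fall in this assay.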